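A few compounds are considered here, and "the series" means these few. Any claim that something is new, unique, unknown or untested is made for them only; others in the source may bear on it.

Measured so far:
compound 1 `O=C(CN(c1nc(Cl)nc2[nH]cnc12)C1CC1)NCC(=O)OCc1ccccc1` with 18%
compound 2 `C[C@@H](O)[C@H](NC(=O)CN(c1ncnc2c1ncn2C1CCCCO1)C1CC1)C(=O)OCc1ccccc1` with 6.53%

Compound 1 stands highest of the two numbers in a functional assay on the whole organism (Tail, strain ICR) with Mus musculus as the target, in the tail flick test, with a stated time of 150 min, at a dose of 25 umol/kg by the oral route; on this read-out lower numbers stand for a weaker effect and higher numbers for a stronger effect at the one dose given; compound 2 lies lower, and the gap between them is beyond the scatter. Compound 3 `O=C(CN(c1nc(Cl)nc2[nH]cnc12)C1CC1)N[C@@H](CO)C(=O)OCc1ccccc1` has not been measured in this assay. It differs from compound 1 by hydroxymethyl in place of hydrogen on a saturated chain carbon bound to an amide-type nitrogen and a carbonyl carbon. For the measured compounds named here, no step between measured compounds covers this change, so only a small shift is expected, if any, and none beyond the scatter. For compound 3 the estimated value is 14%, in the range 4% to 28%, the expected step being a number 4 percentage points lower from compound 1 to compound 3 (within the scatter).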

Compound 3, a percentage reported as activity, at one dose (the size of the read-out at that dose, not a potency): 27.9%
The estimate for compound 3 lay 13.9 percentage points below the measured number, and the stated range covers the measured number.
By their numbers in this assay, from the lowest: compound 2; then compounds 1 and 3 (each within the scatter of the next).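

In this assay, hydroxymethyl in place of hydrogen on a saturated chain carbon bound to an amide-type nitrogen and a carbonyl carbon gives a number 9.9 percentage points higher from compound 1 to compound 3 (within the scatter). This place therefore accepts the group on the core of compound 1 without an effect that can be told from the scatter. No available evidence gives a cause for this result. On these data alone, whether an amine, a carboxylic acid or a longer chain at this carbon would leave the read-out equally unmoved remains open. So does whether a plain methyl would.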